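The source may hold more compounds than are shown below. What is called first, only, known or untested is meant among the compounds shown, and "the series" means these compounds.

Measured compounds in an assay for inhibition of Indoleamine 2,3-dioxygenase 1 (Homo sapiens), with stated times of 10 min and 60 min; a lower number here means a stronger inhibitor, a higher number a weaker inhibitor:
Compound 1 `FC(F)(F)c1cc(NC[C@H]2CCCN2)c2cn[nH]c2c1` gives 9580 nM.
Compound 2 `O=[N+]([O-])c1cc(OCc2ccccc2)ccc1CNc1cc(C(F)(F)F)cc2[nH]ncc12` reaches only a limit of the assay, > 100000 nM.
Compound 3 `O=[N+]([O-])c1ccccc1CNc1cccc2[nH]ncc12` gives "nd" (no result reported), that is, no result reported.

Among the measured compounds shown here, compound 1 therefore holds the only single number among the measured compounds; one further entry is a limit of > 100000 nM in this assay, at which 1 of the 3 values shown sits, and one entry carries no result at all. For the measured compounds named here, no step between measured compounds that differ in one place is available, so nothing measured tells how large a change at this position can be.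

Compound 4 `Nc1cccc(CNc2cc(C(F)(F)F)cc3[nH]ncc23)c1` carries 3-aminophenyl in place of pyrrolidin-2-yl on a saturated chain carbon bound to a nitrogen on an aromatic ring. Going by the values given here, compound 2, the one other compound that has been run, gives only a limit, > 100000 nM. On that thin basis the expectation for compound 4 in this assay is a loss beyond the scatter, a step of a 3.1-fold higher number from compound 1 to compound 4 (0.50 log units; beyond the scatter). Compound 4 is estimated at 30000 nM, with a range from 6000 nM to 150000 nM.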

Compound 4, half-maximal inhibitory concentration: > 100000 nM
Compound 4: a limit, no number (the forecaster's own chance of this, stated with the estimate: 35%); middle value at least 3.3-fold (0.52 log units) away from the limit.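

Among the compounds shown here, replacing pyrrolidin-2-yl with 3-aminophenyl on a saturated chain carbon bound to a nitrogen on an aromatic ring gives the first readable step at this position in this assay: an at least 10-fold higher number from compound 1 to compound 4 (1.01 log units; beyond the scatter). On these data alone, the value of compound 4 is a limit, not a number, so the true size of the step stays unknown. Among the compounds shown, only compound 1 gives a single number, and the limit recurs: the limit of > 100000 nM in this assay, at which 2 of the 4 values shown sit.

Open, as far as these compounds go, is whether piperidin-2-yl or a plain aminoethyl chain at this place would give a single number. Also open, from the compounds shown here alone, is how an unsubstituted phenyl would read out here.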